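Adding a Methyl to the Pyridinyl Ether of Compound 3

This account rests on a few compounds, and the source may have more. Where it says the series, first, only, none or still open, it means among the compounds named here.

Compound 1 `Cc1ccc(Oc2ccc3nc(COc4cccc(C(=O)O)c4)n(C)c3n2)cc1F` gives 2.1 in a physicochemical assay for lipophilicity, read by LC-MS, in phosphate buffer, measured as octanol-water partition, with a stated time of 30 min, at pH 7.4, tested at 200 mM; a lower number here means a more polar compound, a higher number a more lipophilic compound.
Compound 2 `Cc1ccc(Oc2ccc3nc(COc4cccc(C(=O)O)c4)n(C)c3n2)c(C)c1` gives 2.3 in this assay.
Compound 3 `Cn1c(COc2cccc(C(=O)O)c2)nc2ccc(Oc3ccccn3)cc21` gives 0.4 in this assay.

Compound 3 stands lowest of the three, with compound 1 and compound 2 both lying higher by more than the usual scatter. Compound 4 `Cc1cccnc1Oc1ccc2nc(COc3cccc(C(=O)O)c3)n(C)c2c1` differs from compound 3 by methyl in place of hydrogen on an aromatic carbon of a six-membered aromatic ring with 1 nitrogen, ortho to a large group. Within the data shown here, no measured step makes this same change. Among the measured compounds shown here, the only single-difference step, a number 0.20 log units higher from compound 1 to compound 2 (within the scatter), swaps one substituted phenyl for another and offers little guidance here. A single added methyl is therefore expected to raise this assay only modestly, as a number 0.40 log units higher from compound 3 to compound 4 (beyond the scatter). Compound 4 is estimated at 0.8, between 0.4 and 1.2.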

Compound 4, distribution coefficient: 0.9
Beside the measured number, compound 4's estimate is 0.10 log units below it; measured number inside the range.
By their numbers in this assay, from the lowest: compound 3; then compound 4; then compounds 1 and 2 (each within the scatter of the next).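

Among these compounds, this is the first measured step that changes the pyridin-2-yl group itself: in this assay, the swap to 3-methylpyridin-2-yl gives a number 0.50 log units higher from compound 3 to compound 4 (beyond the scatter). A single added methyl on this aromatic carbon, two atoms from the ring nitrogen, is therefore enough to move the number past the usual scatter. Nothing on hand explains the size of this rise.

Still open, going by these compounds, is how a different group on this same carbon, such as an ethyl, a methoxy or a chlorine, would compare with the methyl. Also open, on these data alone, is whether a methyl on another carbon of this ring would give a similar step.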